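The compounds below may be only part of what the source reports. "The series", "measured", "known", "first", "only" and "open" are said of these compounds alone.

Measured compounds:
Compound 1 `Cc1cc(C(=O)NCc2ccccc2)nn1Cc1cc(Cl)ccc1OCc1ccccc1`: in a physicochemical assay for lipophilicity, at pH 7.4 (on this read-out higher numbers stand for higher lipophilicity and lower numbers for lower lipophilicity), compound 1 reaches the limit > 3.7.
Compound 2 `Cc1cc(NC(=O)C2CCOC2)nn1Cc1cc(Cl)ccc1OCc1ccccc1`: in this assay compound 2 likewise reaches the limit > 3.7.
Compound 3 `Cc1cc(NC(=O)OC(C)(C)C)nn1Cc1cc(Cl)ccc1OCc1ccccc1`: in this assay compound 3 likewise reaches the limit > 3.7.

Compound 3 therefore stands at the upper limit of this assay, and the two further values shown sit at that same limit (the limit of > 3.7 in this assay, at which 3 of the 3 values shown sit). All three readings are limits rather than numbers, so none of the steps among these compounds can be read as a size: a step that the two limits leave unreadable from compound 1 to compound 2, a step that the two limits leave unreadable from compound 1 to compound 3 and a step that the two limits leave unreadable from compound 2 to compound 3 all remain open in both size and direction.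

Compound 4 `Cc1cc(NC(=O)OCc2ccccn2)nn1Cc1cc(Cl)ccc1OCc1ccccc1` differs from compound 3 by (pyridin-2-yl)methyl in place of tert-butyl on an oxygen next to a carbonyl group. Among the measured compounds shown here, none of the measured steps changes this oxygen, and none of them yields a readable size, so no measured step can anchor an expectation for this change. For the measured compounds named here, what is known is only that compound 3 sits at the limit, so this assay may well report only a limit again for compound 4. The step is expected to be a number at least 0.10 log units lower from compound 3 to compound 4 (that floor lies within the scatter). Compound 4 is accordingly estimated at 3.6, with a range from 3 to 4.2.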

Compound 4, distribution coefficient: 3.1
For compound 4 the middle estimate is 0.50 log units above the measured one; measured number inside the range.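

Among the compounds shown here, the change from tert-butyl to (pyridin-2-yl)methyl on an oxygen next to a carbonyl group is the first in this set to bring a reading off the limit in this assay, and it gives a number at least 0.60 log units lower from compound 3 to compound 4 (beyond the scatter). The comparisons with the other two compounds read the same way, as a number at least 0.60 log units lower from compound 2 to compound 4 (beyond the scatter) and as a number at least 0.60 log units lower from compound 1 to compound 4 (beyond the scatter), so this place on the molecule can carry a change that shows up as a number in this assay, even with the shared core left as it is. Each of these steps is only a floor, and the steps among the three earlier compounds cannot be read at all, because their readings are limits: the limit of > 3.7 in this assay, at which 3 of the 4 values shown sit.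

Going by these compounds, how much of the step belongs to the ring nitrogen and how much to the ring itself stays open, and a benzyl group on this oxygen would separate the two. Also open, on these data alone, are the true size of the step and how a methyl group, or a longer chain ending in an amine or a carboxylic acid, would read at this place.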